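This account rests on a few compounds, and the source may have more. Where it says the series, first, only, none or still open, it means among the compounds named here.

Compound 3, drawn as `O=C(/C(=C\c1c(O)cc(O)cc1O)SCc1ccc(Cl)c(Cl)c1)c1ccc(Cl)cc1`, is the starting point here. In a functional assay on DU-145 cells (Homo sapiens) for inhibition, read by trypan blue exclusion, with a stated time of 96 h (a higher number here means a weaker inhibitor of growth, a lower number a stronger inhibitor of growth), compound 3 gives 25000 nM, which puts it level with compound 1 at the digits shown, the two together standing at the highest number of the three measured. Compound 1, `Cc1ccc(S(=O)(=O)/C(=C/c2cccs2)C(=O)c2ccc(Cl)cc2)cc1`, gives 25000 nM in this assay, and compound 2, `Cc1ccc(S(=O)(=O)/C(=C/c2sccc2C)C(=O)c2ccc(Cl)cc2)cc1`, gives 10000 nM. Within the data shown here, the one measured step, a 2.5-fold lower number from compound 1 to compound 2 (0.40 log units; beyond the scatter), is the only change on the file, and it concerns a different part of the molecule.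

Compound 4, `Cc1ccc(S(=O)(=O)/C(=C/c2c(O)cc(O)cc2O)C(=O)c2ccc(Cl)cc2)cc1`, is not yet measured. It differs from compound 3 by (4-methylphenyl)sulfonyl in place of (3,4-dichlorobenzyl)sulfanyl on a double-bonded chain carbon bound to a carbonyl carbon and a double-bonded chain carbon. Among the measured compounds shown here, no measured pair tells how a (4-methylphenyl)sulfonyl compares against a (3,4-dichlorobenzyl)sulfanyl at this position; compound 1 and compound 2 carry the (4-methylphenyl)sulfonyl already, and their numbers show only that this group allows growth inhibition in the same broad range as compound 3. The step from compound 3 to compound 4 is therefore expected to stay within the scatter, with no clear direction, estimated as a 1.3-fold lower number from compound 3 to compound 4 (0.10 log units; within the scatter). Compound 4 is estimated to give 20000 nM in this assay, with an expected range from 5000 nM to 60000 nM.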

Compound 4, concentration for 50% growth inhibition: > 100000 nM
Compound 4: a limit, no number; the forecaster's own chance of this, stated with the estimate: 20%; at least 5.0-fold (0.69 log units) between middle value and limit.
By their numbers in this assay, from the lowest: compound 2; then compounds 1 and 3 (each within the scatter of the next). At a limit, above all of these: compound 4.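

In this assay compound 4 carries a limit and not a number: the limit of > 100000 nM in this assay, at which 1 of the 4 values shown sits. Among these compounds, with the 2,4,6-trihydroxyphenyl held fixed, (4-methylphenyl)sulfonyl in place of (3,4-dichlorobenzyl)sulfanyl on a double-bonded chain carbon bound to a carbonyl carbon and a double-bonded chain carbon gives an at least 4.0-fold higher number from compound 3 to compound 4 (0.60 log units; beyond the scatter), the first direct reading of this swap at this position. With the (4-methylphenyl)sulfonyl held fixed, 2,4,6-trihydroxyphenyl in place of thiophen-2-yl gives an at least 4.0-fold higher number from compound 1 to compound 4 (0.60 log units; beyond the scatter), and in place of 3-methylthiophen-2-yl it gives an at least 10-fold higher number from compound 2 to compound 4 (1.00 log units; beyond the scatter), so the growth inhibition seen with this sulfonyl group in the two thiophene compounds does not carry over to the 2,4,6-trihydroxyphenyl compound.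

Still open, as far as these compounds go, is how the (3,4-dichlorobenzyl)sulfanyl would behave with a thiophen-2-yl in place of the 2,4,6-trihydroxyphenyl, which would show whether the sulfanyl group or the ring decides the outcome. Also open, from the compounds shown here alone, is whether a plain phenyl or a 4-aminophenyl at that same place would bring the (4-methylphenyl)sulfonyl series back towards the level of compound 1.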